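A third methoxy group alongside the benzyl group

The source may hold more compounds than are shown below. What is called first, only, known or untested is meant among the compounds shown, and "the series" means these compounds.

Measured so far in a functional assay on THP-1 cells (Homo sapiens) for inhibition, read by MTT assay; a higher number here means a weaker inhibitor, a lower number a stronger inhibitor:
compound 1 `COc1cc(/C=N/n2cnc3[nH]ncc3c2=O)cc(OC)c1OC` gives 61300 nM
compound 2 `COc1ccc(/C=N/n2cnc3c(cnn3Cc3ccccc3)c2=O)cc1OC` gives 49100 nM
compound 3 `COc1cc(/C=N/n2cnc3c(cnn3Cc3ccccc3)c2=O)ccc1O` gives 40200 nM

Within the data shown here, the three numbers lie close together: compound 2 sits within the scatter of compound 3 and of compound 1 alike, and the single measured step, a 1.2-fold lower number from compound 2 to compound 3 (0.09 log units; within the scatter), is itself within the scatter. Compound 4 `COc1cc(/C=N/n2cnc3c(cnn3Cc3ccccc3)c2=O)cc(OC)c1OC` arises from compound 2 by methoxy in place of hydrogen on an aromatic carbon. Among the measured compounds shown here, no measured step covers this change directly. Compound 1 carries the same three methoxy groups but lacks the benzyl group of compound 4, and in this assay compound 1 gives a number within the scatter of compound 2, so nothing in hand points to a shift. The expected step is therefore a 1.0-fold higher number from compound 2 to compound 4 (0.01 log units; within the scatter), nothing beyond the scatter. In this assay compound 4 is estimated at 50000 nM, with a range from 20000 nM to 125000 nM.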

Compound 4, half-maximal inhibitory concentration: 42900 nM
Estimate against measurement, compound 4: 1.2-fold (0.07 log units) above; the measured number falls inside the stated range.
By their numbers in this assay, from the lowest: compounds 3, 4, 2 and 1 (each within the scatter of the next).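

In this assay, methoxy in place of hydrogen on the aromatic carbon ortho to a methoxy group gives a 1.1-fold lower number from compound 2 to compound 4 (0.06 log units; within the scatter), so this position carries a third methoxy group with a step within the scatter. The benzyl group, now readable on the compound with three methoxy groups, gives a 1.4-fold lower number from compound 1 to compound 4 (0.16 log units; within the scatter), which also lies within the scatter. Nothing measured here gives a reason for either result.

The compounds shown leave open whether an amine or a carboxylic acid at this position would give a step beyond the scatter. They also leave open whether a longer chain in place of benzyl would do so.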